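Swapping a bromophenyl for a pyridinyl on the shared core

The source may report more compounds than this note shows. Statements on the series, on what has been measured and on what is new or still open speak of the compounds shown alone.

Three compounds share one core and differ only in the group on a saturated ring carbon. Compound 1 `O=C(NN1CCOCC1)C1=NN(c2ccc(Cl)cc2Cl)C(c2ccccc2)C1` carries a plain phenyl there; in a functional assay on the whole organism (strain Zucker) for inhibition, with Rattus norvegicus as the target, with a stated time of 4 h, at a dose of 10 mg/kg by the oral route (on this read-out higher numbers stand for more inhibition at the one dose given (going by the name of the read-out) and lower numbers for less inhibition), compound 1 gives 31.9%. Compound 2 `COc1ccc(C2CC(C(=O)NN3CCOCC3)=NN2c2ccc(Cl)cc2Cl)cc1` adds a methoxy, and compound 2 gives 9.4%. Compound 3 `O=C(NN1CCOCC1)C1=NN(c2ccc(Cl)cc2Cl)C(c2ccc(Br)cc2)C1` adds a bromo instead, and compound 3 gives 24.2%. Compound 3 thus sits within the scatter of compound 1 and clearly above compound 2: the step of a number 7.7 percentage points lower from compound 1 to compound 3 (within the scatter) is within the scatter, while the step of a number 14.8 percentage points higher from compound 2 to compound 3 (beyond the scatter) is a modest gain.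

Compound 4 `O=C(NN1CCOCC1)C1=NN(c2ccc(Cl)cc2Cl)C(c2cccnc2)C1` changes the same position again: pyridin-3-yl in place of 4-bromophenyl on a saturated ring carbon. Among the compounds with values here, no measured step exchanges a phenyl for a pyridinyl, so the two steps above only show that small changes at this position have left the number level in one case and moved it modestly in the other. The step of a number 2.2 percentage points lower from compound 3 to compound 4 (within the scatter) is therefore expected to stay within the scatter. Compound 4 is estimated at 22%, with a range from 8% to 36%.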

Compound 4, a percentage reported as inhibition, in the whole organism at one dose (the size of the read-out at that dose, not a potency): 4%
For compound 4 the middle estimate is 18 percentage points above the measured one, outside the stated range (below it).
By their numbers in this assay, from the lowest: compounds 4 and 2 (each within the scatter of the next); then compounds 3 and 1 (each within the scatter of the next).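

In this assay the change to pyridin-3-yl, a ring with a hetero atom at this position, gives a number 20.2 percentage points lower from compound 3 to compound 4 (beyond the scatter) and a number 27.9 percentage points lower from compound 1 to compound 4 (beyond the scatter), so this position does not accept every six-membered aromatic ring equally. The change from the 4-methoxyphenyl ring gives a number 5.4 percentage points lower from compound 2 to compound 4 (within the scatter), which places the pyridin-3-yl and 4-methoxyphenyl groups at one level and shows that two quite different rings can end up equally low here. No measurement at hand explains the loss seen with the ring nitrogen.

Still open, from the compounds shown here alone, is whether other rings with a hetero atom, such as thienyl or pyrimidinyl, behave like pyridin-3-yl. A cyclohexyl group would show whether an aromatic ring is needed at this position at all.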